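The compounds below may be only part of what the source reports. "The series", "measured", "known", "first", "only" and "open" are said of these compounds alone.

Of the compounds shown here, three have been tested in a functional assay on HCT-116 cells (Homo sapiens) for cytotoxicity, read by WST assay, with a stated time of 48 h; on this read-out higher numbers stand for weaker inhibition and lower numbers for stronger inhibition. Compound 1 `Cc1cc2c(c(=O)[nH]1)OC(C(=O)CC(C)C)O2` is reported in this assay only as a limit, > 100000 nM. Compound 2 `CC(C)CC(=O)[C@@H]1O[C@@]12C(=O)C=C(Cc1ccccc1)NC2=O` likewise returns only a limit in this assay, > 100000 nM. Compound 3 `CC(C)C[C@]1(O)NC(=O)[C@]2(OC(Cc3ccccc3)=CC2=O)[C@H]1O` also gives no number in this assay but a limit, > 100000 nM. Compound 3 thus stands nowhere apart from the other two, since every value rests on (the limit of > 100000 nM in this assay, at which 3 of the 3 values shown sit). Compound 4 `CC1=CC(=O)[C@]2(O1)C(=O)N[C@@](O)(CC(C)C)[C@@H]2O` differs from compound 3 by hydrogen in place of phenyl on a saturated chain carbon bound to a double-bonded ring carbon. Among the measured compounds shown here, no step between measured compounds is available, so the step that the limit leaves unreadable from compound 3 to compound 4 is expected to be small, without a clear direction and not beyond the usual scatter. In this assay compound 4 is therefore expected to give about 150000 nM, between 50000 nM and 500000 nM.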

Compound 4, half-maximal inhibitory concentration: > 100000 nM
Compound 4: only a limit was reported; the forecaster's own chance of this, stated with the estimate: 85%; the middle value does not contradict the limit.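

No step can be read between compound 3 and compound 4, as both are reported only as limits: the limit of > 100000 nM in this assay, at which 4 of the 4 values shown sit. The compounds shown leave open what hydrogen in place of phenyl does to potency in this assay, and whether any of them reaches a measurable value there.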